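Chloro to methoxy on the aryl group of compound 2

The compounds below may be only part of what the source reports. "The series", "measured", "known", "first", "only" and "open" are said of these compounds alone.

compound 1 `O=C(Nc1nc2ccc(F)cc2s1)c1cn(-c2ccccc2)nc1-c1ccc(F)cc1`: 12500 nM
compound 2 `O=C(Nc1nc2ccc(F)cc2s1)c1cn(-c2ccccc2)nc1-c1ccc(Cl)cc1`: 7770 nM

For the measured compounds named here, in a functional assay on U-87MG ATCC cells for cytotoxicity against U-87 MG (Homo sapiens), read by MTT assay, with a stated time of 72 h (on this read-out lower numbers stand for stronger inhibition and higher numbers for weaker inhibition), compound 2 gives 7770 nM, compound 1 gives 12500 nM; the single step of a 1.6-fold lower number from compound 1 to compound 2 (0.21 log units; within the scatter) leaves the two not separated, so compound 2 stands at one end of a pair that the scatter does not resolve. Compound 3 `COc1ccc(-c2nn(-c3ccccc3)cc2C(=O)Nc2nc3ccc(F)cc3s2)cc1` carries methoxy in place of chloro on an aromatic carbon. Going by the values given here, no measured step covers methoxy against chloro; the halogen-for-halogen step stayed within the scatter, so the expected step of a 1.3-fold higher number from compound 2 to compound 3 (0.11 log units; within the scatter) is none beyond scatter. Compound 3 is estimated at 10000 nM, range 3000 nM to 35000 nM.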

Compound 3, half-maximal inhibitory concentration: 8990 nM
The estimate for compound 3 lay 1.1-fold (0.05 log units) above the measured number; the measured number falls inside the stated range.
By their numbers in this assay, from the lowest: compounds 2, 3 and 1 (each within the scatter of the next).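

Methoxy in place of chloro on an aromatic carbon, para to a large group, gives a 1.2-fold higher number from compound 2 to compound 3 (0.06 log units; within the scatter) in this assay and methoxy in place of fluoro gives a 1.4-fold lower number from compound 1 to compound 3 (0.14 log units; within the scatter) at the same place. The earlier pair held halogens only; this place now also takes a group entering with carbon and oxygen, without separation from either halogen. No measurement at hand speaks to why these three compounds stay together.

Open, on these data alone, is whether an amine, a carboxylic acid or a longer chain at this place would separate from compound 1, compound 2 and compound 3. Also open, as far as these compounds go, is whether any group here moves the number beyond the scatter at all.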